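The source may report more compounds than this note shows. Statements on the series, on what has been measured and on what is new or still open speak of the compounds shown alone.

Series notes. The read-out throughout is a functional assay with Alpha-1B adrenergic receptor (Homo sapiens) as the target, read by calcium flux; on this read-out lower numbers stand for smaller maximal responses and higher numbers for larger maximal responses. Compound 1 `CCn1cccc1-c1ccccc1NCC1=NCCN1` gives 0% in this assay. Compound 2 `CCn1ccc(-c2ccccc2NCC2=NCCN2)n1` gives 0% in this assay. On these numbers compound 1 stands level with compound 2 at the digits shown, with no difference beyond the usual scatter, so neither shows any maximal response in this assay. Among the compounds with values here, no further pair differing in one place has been measured.

Compound 3 `Cn1cccc1-c1ccccc1NCC1=NCCN1` is the next member and awaits measurement in this assay. It differs from compound 1 by hydrogen in place of methyl on a saturated chain carbon bound to an aromatic nitrogen. Nothing measured in the series speaks for a step of any size from this change, and the two measured compounds sit at the floor of the read-out, so no step beyond the scatter is expected. The step from no change at the digits printed from compound 1 to compound 3 (within the scatter) is expected to be none beyond the scatter. Compound 3 is therefore estimated at 0%, within 0% to 10%, in this assay.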

Compound 3, largest response reached (reported as maximal response), in percent of the reference or control that the assay uses: 0%
For compound 3 middle estimate and measured number coincide at the digits printed; the measured number falls inside the stated range.
By their numbers in this assay, from the lowest: compounds 1, 2 and 3 (each within the scatter of the next).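

Hydrogen in place of methyl on a saturated chain carbon bound to an aromatic nitrogen gives the first step in the series between compounds that differ in one place, and in this assay it reads no change at the digits printed from compound 1 to compound 3 (within the scatter). Cutting ethyl to methyl at this place therefore brings no maximal response into view, with compound 3 at 0%, but a step between two compounds without any response cannot show how much this place matters. Nothing at hand bears on the reason for this result.

Going by these compounds, whether a longer chain such as propyl, or an amine or a carboxylic acid at this place, would give any response in this assay remains open. So does the size of this same change on a compound that does give a response.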